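The source may hold more compounds than are shown below. What is called first, only, known or untested is meant among the compounds shown, and "the series" means these compounds.

Working notes on the series. Three members of the series have numbers in an assay on HEK293 cells for agonist activity at transient receptor potential cation channel subfamily M member 8 (Homo sapiens), read by fluorescence and calcium flux, with a stated time of 15 min; a higher number here means that more compound is needed for the effect, a lower number that less compound is needed: compound 1 `Cc1ccc(OCC(=O)N(Cc2cccs2)C2CCCCC2)cc1` gives 40000 nM, compound 2 `CON(Cc1cccs1)C(=O)COc1ccc(C)cc1` gives 10 nM, and compound 3 `Cc1ccc(OCC(=O)N(Cc2cccs2)c2ncccn2)cc1` gives 3700 nM. Compound 3 thus stands second highest of the three numbers in this assay, nearest to compound 1 and furthest from compound 2. Every change measured so far sits on the same amide-type nitrogen and every one of them is large: a 4000-fold lower number from compound 1 to compound 2 (3.60 log units; beyond the scatter), an 11-fold lower number from compound 1 to compound 3 (1.03 log units; beyond the scatter) and a 370-fold higher number from compound 2 to compound 3 (2.57 log units; beyond the scatter). Compound 4 `Cc1ccc(OCC(=O)N(Cc2cccs2)c2ccon2)cc1` is not yet measured; it differs from compound 3 at that same nitrogen, (1,2-oxazol-3-yl in place of pyrimidin-2-yl on an amide-type nitrogen). Among the compounds with values here, no measured step swaps one aromatic ring for another at this position, so none bears on the change directly; what the three steps show is only that the position responds strongly to what is attached there. With both rings carrying the same count of acceptors and no donors, the working expectation for compound 4 in this assay is a step of modest size, a 1.5-fold lower number from compound 3 to compound 4 (0.17 log units; within the scatter), in either direction, not clearly beyond the scatter. Compound 4 is estimated at 2500 nM, within a range of 400 nM to 15000 nM.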

Compound 4, half-maximal effective concentration: 2 nM
For compound 4 the middle estimate is 1300-fold (3.10 log units) above the measured one; measured number outside the range, below it.
By their numbers in this assay, from the lowest: compound 4; then compound 2; then compound 3; then compound 1.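

The ring swap on the amide-type nitrogen is far from neutral in this assay: two aromatic rings with equal counts of hydrogen-bond donors and acceptors give a 1900-fold lower number from compound 3 to compound 4 (3.27 log units; beyond the scatter), so these counts do not settle the outcome at this position, and neither does the mere presence of an aromatic ring. Until now, methoxy carried the lowest number of the series, whereas the 1,2-oxazol-3-yl ring goes lower still with a 5.0-fold lower number from compound 2 to compound 4 (0.70 log units; beyond the scatter), a modest step, so a ring at this position is compatible with the lowest number among the four compounds. The span across the position also widens, with a 20000-fold lower number from compound 1 to compound 4 (4.30 log units; beyond the scatter), and no available evidence accounts for the size of any of these steps.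

Pyrimidin-2-yl and 1,2-oxazol-3-yl differ at once in ring size and in hetero atoms, so compounds 3 and 4 cannot separate the contribution of each. Where a phenyl or 1,3-thiazol-2-yl ring would fall on this nitrogen remains open, as does whether an ethoxy group would stay close to the methoxy of compound 2.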